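Replacing the 4-chlorophenyl group of compound 3

This account rests on a few compounds, and the source may have more. Where it says the series, first, only, none or still open, it means among the compounds named here.

Compound 1 `COc1cc(-c2nc(-c3ccccc3)[nH]c2-c2ccnc(NCCCNS(=O)(=O)c3ccccc3)n2)ccc1F`: 4520 nM
Compound 2 `COc1cc(-c2nc(-c3ccccc3)[nH]c2-c2ccnc(NCCCNS(=O)(=O)c3ccc(Cl)cc3)n2)ccc1F`: 83100 nM
Compound 3 `COc1cc(-c2nc(-c3ccccc3)[nH]c2-c2ccnc(NCCCNS(=O)(=O)c3ccc(Cl)cc3)n2)ccc1Cl`: 60900 nM

In a functional assay on LOX IMVI cells (Homo sapiens) for cytotoxicity, read by MTT assay, with a stated time of 24 h (on this read-out lower numbers stand for stronger inhibition and higher numbers for weaker inhibition), compound 3 gives 60900 nM, a number within the usual scatter of compound 2 and far higher than that of compound 1. The next structure is compound 4 `COc1cc(-c2nc(-c3ccccc3)[nH]c2-c2ccnc(NCCCNS(=O)(=O)c3cccc4ccccc34)n2)ccc1Cl`, and the change is naphthalen-1-yl in place of 4-chlorophenyl on a sulfonyl sulfur.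

Among the compounds with values here, no measured step makes this exact swap. The closest evidence is an 18-fold higher number from compound 1 to compound 2 (1.26 log units; beyond the scatter), a large step made by chloro in place of hydrogen on the group attached to the sulfonyl sulfur. Compound 4 lacks that chloro but carries a second ring, so this step offers only partial guidance. The other step, a 1.4-fold lower number from compound 2 to compound 3 (0.13 log units; within the scatter), lies elsewhere in the molecule and within the scatter, so it says little here.

A moderate move towards lower numbers in this assay therefore seems likely, though the direction is uncertain. The expected change is a 2.4-fold lower number from compound 3 to compound 4 (0.39 log units; beyond the scatter). For compound 4, the estimated value is 25000 nM, with an expected range from 5000 nM to 100000 nM.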

Compound 4, half-maximal inhibitory concentration: 13500 nM
Beside the measured number, compound 4's estimate is 1.9-fold (0.27 log units) above it, within the range that was stated.
By their numbers in this assay, from the lowest: compound 1; then compound 4; then compounds 3 and 2 (each within the scatter of the next).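

In this assay, within the data shown here, the group on the sulfonyl sulfur proves open to a larger change than the earlier compounds showed, with naphthalen-1-yl in place of 4-chlorophenyl giving a 4.5-fold lower number from compound 3 to compound 4 (0.65 log units; beyond the scatter) in this series. Until now, the only change shown at this group was the added chloro, which gave an 18-fold higher number from compound 1 to compound 2 (1.26 log units; beyond the scatter) and moved the number the opposite way, so this position can shift the read-out in either direction. Nothing measured here explains why the number falls with this swap.

The swap removes the chloro and adds a second aromatic ring at once, so the compounds shown cannot separate the two contributions. From the compounds shown here alone, how a small group such as methyl, or a pyridine ring, would read on the sulfonyl sulfur remains open.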